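This account rests on a few compounds, and the source may have more. Where it says the series, first, only, none or still open, it means among the compounds named here.

Compound 1 `CC(C)(C)CCn1nc(-c2cccs2)c(O)c(C2=NS(=O)(=O)c3cc(NS(C)(=O)=O)ccc3N2)c1=O`: > 1000 nM
Compound 2 `CS(=O)(=O)Nc1ccc2c(c1)S(=O)(=O)N=C(c1c(O)c(-c3cccs3)nn(CC3CCC3)c1=O)N2`: > 1000 nM
Compound 3 `CC(C)(C)Cn1nc(-c2cccs2)c(O)c(C2=NS(=O)(=O)c3cc(NS(C)(=O)=O)ccc3N2)c1=O`: > 1000 nM

In an ADME assay on Huh-7 cells (Homo sapiens) for cytotoxicity, with a stated time of 72 h (a higher number here means that more compound is tolerated, a lower number that less compound is tolerated), compound 3 gives > 1000 nM, which is a limit and not a number. Compounds 1 and 2 also stand only at limits, as the limit of > 1000 nM in this assay, at which 3 of the 3 values shown sit, shows. Compound 4 `CS(=O)(=O)Nc1ccc2c(c1)S(=O)(=O)N=C(c1c(O)c(-c3cccs3)nn(Cc3ccccc3)c1=O)N2` differs from compound 3 by phenyl in place of tert-butyl on a saturated chain carbon bound to an aromatic nitrogen. Three measured steps change the same group: a step that the two limits leave unreadable from compound 1 to compound 3, a step that the two limits leave unreadable from compound 2 to compound 3 and a step that the two limits leave unreadable from compound 1 to compound 2. Going by the values given here, none of them has a readable size, so they offer no measured precedent for a shift. No step beyond the scatter is therefore expected in this assay, and no direction can be given. The expected change is a step that the limit leaves unreadable from compound 3 to compound 4. For compound 4 the estimated value is 2000 nM, with an expected range from 1000 nM to 10000 nM.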

Compound 4, half-maximal cytotoxic concentration: > 1000 nM
Compound 4: only a limit was reported (the forecaster's own chance of this, stated with the estimate: 90%); the middle value does not contradict the limit.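

Going by these compounds alone, compound 4, like compounds 1, 2 and 3, gives only a limit in this assay, so no step involving compound 4 can be read: the limit of > 1000 nM in this assay, at which 4 of the 4 values shown sit. The compounds shown leave open whether phenyl, tert-butyl, cyclobutyl or neopentyl in this place makes any difference in this assay.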